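The compounds below may be only part of what the source reports. "The series", "measured", "known", "first", "only" and "open" are said of these compounds alone.

Series notes, a functional assay on K562 cells (Homo sapiens) for antiproliferative activity, read by MTT assay, with a stated time of 48 h; on this read-out lower numbers stand for stronger inhibition and higher numbers for weaker inhibition. Compound 1 `CC[C@@H](C)[C@H](NC(=O)c1ccc(Oc2nc3ccccc3nc2C)cc1)C(=O)OC` gives 38300 nM in this assay. Compound 2 `Cc1nc2ccccc2nc1Oc1ccc(C(=O)N[C@@H](C)C(=O)O)cc1` gives 28100 nM. Compound 3 `CCCCCCCCCCCCNc1nc2ccccc2nc1Oc1ccc(C(=O)N[C@H](C(=O)OC)[C@H](C)CC)cc1` gives 30800 nM. The three numbers lie close together, and none of the compounds can be singled out as more or less active than the others.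

Among the measured compounds shown here, the one counted change within the measured set is 1-carboxyethyl in place of 1-(methoxycarbonyl)-2-methylbutyl on an amide-type nitrogen, and it moved the read-out by a 1.4-fold lower number from compound 1 to compound 2 (0.13 log units; within the scatter). Compound 4 `CCCCCCCCCCCCNc1nc2ccccc2nc1Oc1ccc(C(=O)N[C@@H](C)C(=O)O)cc1` carries the same change on the core of compound 3: 1-carboxyethyl in place of 1-(methoxycarbonyl)-2-methylbutyl on an amide-type nitrogen. The place of the change is the same in both pairs, an amide-type nitrogen whose other neighbour is a carbonyl carbon. How the core of compound 3 differs from the core of compound 1 is not broken down here; their values show only that they sit within the scatter of each other.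

For compound 4 a step of about the same small size is expected, a 1.3-fold lower number from compound 3 to compound 4 (0.11 log units; within the scatter), because the same change from compound 1 to compound 2 gave a 1.4-fold lower number from compound 1 to compound 2 (0.13 log units; within the scatter). The estimate for compound 4 is 24000 nM, with a range from 12000 nM to 48000 nM.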

Compound 4, half-maximal inhibitory concentration: 3280 nM
Estimate against measurement, compound 4: 7.3-fold (0.86 log units) above; measured number outside the range, below it.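

In this assay, 1-carboxyethyl in place of 1-(methoxycarbonyl)-2-methylbutyl on an amide-type nitrogen gives a 9.4-fold lower number from compound 3 to compound 4 (0.97 log units; beyond the scatter) and does not carry over at a constant size from one core to the other: the same change on two cores in this assay, a 1.4-fold lower number (0.13 log units; within the scatter) from compound 1 to compound 2 and a 9.4-fold lower number (0.97 log units; beyond the scatter) from compound 3 to compound 4, 6.9-fold (0.84 log units) apart, beyond the scatter of two such steps. In these two pairs, the step lies beyond the scatter only on the core of compound 3, so its size cannot be read across from the core of compound 1. Two pairs do not show which feature of the core of compound 3 goes with the larger step, nor whether the same difference would appear on any further core.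

The change swaps the end group and the side chain together, so 1-(methoxycarbonyl)ethyl or 1-carboxy-2-methylbutyl on the core of compound 3 would be needed to separate the carboxylic acid from the shorter side chain. As far as these compounds go, it also remains open how the step would behave with a shorter alkyl chain in place of the long chain of compound 3.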